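Working notes: 2-nitrophenyl in place of 4-fluorophenyl

The source may hold more compounds than are shown below. What is called first, only, known or untested is meant among the compounds shown, and "the series" means these compounds.

For the measured compounds named here, the series so far holds compound 1 `O=C(N/N=C/c1ccccc1)c1cn(C2CC2)c2cc(N3CCNCC3)c(F)cc2c1=O` and compound 2 `O=C(N/N=C/c1ccc(F)cc1)c1cn(C2CC2)c2cc(N3CCNCC3)c(F)cc2c1=O`, both tested in a functional assay on HL-60 cells (Homo sapiens) for antiproliferative activity, read by MTT assay; on this read-out lower numbers stand for stronger inhibition and higher numbers for weaker inhibition. Compound 1 gives <= 25000 nM, which is a limit of the assay and not a number. Compound 2 gives <= 25000 nM, which is likewise a limit. Compound 2 therefore has no exact position on the scale, and the whole record so far is the limit of <= 25000 nM in this assay, at which 2 of the 2 values shown sit.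

The next entry is compound 3 `O=C(N/N=C/c1ccccc1[N+](=O)[O-])c1cn(C2CC2)c2cc(N3CCNCC3)c(F)cc2c1=O`, with 2-nitrophenyl in place of 4-fluorophenyl on a carbon with a double bond to nitrogen. Going by the values given here, the only measured step on this aromatic ring is a step that the two limits leave unreadable from compound 1 to compound 2, so it offers no size or direction to carry over. Among the compounds with values here, no step of definite size or direction can therefore be expected in this assay, and the working expectation is that compound 3 stays in the same region. The expected step, held with low confidence, is a step that the limit leaves unreadable from compound 2 to compound 3. The estimated value for compound 3 is 15000 nM, with an expected range of 3000 nM to 25000 nM.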

Compound 3, half-maximal inhibitory concentration: <= 25000 nM
Compound 3 gave a limit, no number; the forecaster's own chance of this, stated with the estimate: 60%; the middle value does not contradict the limit.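

In this assay no step can be read among compound 1, compound 2 and compound 3, as all three values are limits and not numbers: the limit of <= 25000 nM in this assay, at which 3 of the 3 values shown sit.

The compounds shown leave open how far apart compound 1, compound 2 and compound 3 lie on this read-out, and whether 2-nitrophenyl and 4-fluorophenyl differ at all.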